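Pyridazinone amides on a shared thienopyrimidine ether core

A few compounds are considered here, and "the series" means these few. Any claim that something is new, unique, unknown or untested is made for them only; others in the source may bear on it.

Measured so far:
compound 1 `Cc1ccc(-n2nc(C(=O)Nc3ccc(Oc4ncnc5sccc45)cc3)c(C)cc2=O)cc1` — > 40000 nM
compound 2 `Cc1cc(=O)n(-c2ccccc2OC(F)(F)F)nc1C(=O)Nc1ccc(Oc2ncnc3sccc23)c(F)c1` — > 40000 nM

In a functional assay on A549 cells (Homo sapiens) for cytotoxicity, read by MTT assay, with a stated time of 72 h (on this read-out lower numbers stand for stronger inhibition and higher numbers for weaker inhibition), compound 2 gives > 40000 nM; this is a limit of the assay, not a number. Compound 1 gives > 40000 nM in this assay, again a limit rather than a number. Both values shown therefore sit at the limit of > 40000 nM in this assay, at which 2 of the 2 values shown sit.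

Compound 3 `Cc1ccc(-n2nc(C(=O)Nc3ccc(Oc4ncnc5sccc45)c(F)c3)c(C)cc2=O)cc1` differs from compound 2 by 4-methylphenyl in place of 2-(trifluoromethoxy)phenyl on an aromatic nitrogen. Going by the values given here, no step between measured compounds is available to size this change. With compound 2 at the limit, the expected step is a number no higher from compound 2 to compound 3 (the limit leaves the size open), none beyond the scatter. Compound 3 is estimated at 40000 nM, within 15000 nM to 100000 nM, most probably reported as a limit again.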

Compound 3, half-maximal inhibitory concentration: > 40000 nM
Compound 3 ended at the assay's limit (the forecaster's own chance of this, stated with the estimate: 75%); the middle value lies on the limit itself.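

Going by these compounds alone, no step among compound 1, compound 2 and compound 3 can be read in this assay, as all three values are limits: the limit of > 40000 nM in this assay, at which 3 of the 3 values shown sit. From the compounds shown here alone, whether 4-methylphenyl in place of 2-(trifluoromethoxy)phenyl, or fluoro in place of hydrogen, changes the read-out stays open.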